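The source may report more compounds than this note shows. Statements on the series, on what has been measured and on what is new or still open speak of the compounds shown alone.

Measured in an ADME assay on the whole organism (plasma) for pharmacokinetics, with Rattus norvegicus as the target; a higher number here means faster removal of the compound, a lower number slower removal:

- compound 1 `CCS(=O)(=O)n1cc2c(n1)CN([C@H]1CO[C@H](c3cc(F)ccc3F)[C@@H](N)C1)C2` gives 1.6 mL/min/kg
- compound 2 `CC(C)S(=O)(=O)n1cc2c(n1)CN([C@H]1CO[C@H](c3cc(F)ccc3F)[C@@H](N)C1)C2` gives 7 mL/min/kg
- compound 3 `N[C@H]1C[C@@H](N2Cc3cnn(S(=O)(=O)C4CCCC4)c3C2)CO[C@@H]1c1cc(F)ccc1F` gives 96 mL/min/kg

Among these three numbers, compound 2 at 7 mL/min/kg stands second highest, above compound 1 and below compound 3. Its neighbour still to be measured is compound 4 `N[C@H]1C[C@@H](N2Cc3cn(S(=O)(=O)C4CCCC4)nc3C2)CO[C@@H]1c1cc(F)ccc1F`, which has cyclopentyl in place of isopropyl on a sulfonyl sulfur.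

For the measured compounds named here, only one measured step bears directly on this change. It is a 4.4-fold higher number from compound 1 to compound 2 (0.64 log units; beyond the scatter), a modest rise beyond the scatter, and it also alters the carbon group on the sulfonyl sulfur. Going by the values given here, compound 3 also carries cyclopentyl on a sulfonyl sulfur and gives 96 mL/min/kg, but no single-place step ties it to compound 2, so it serves only as a loose guide to how high the number might go. A single step is thin support for a trend, and the data hold no direct measurement of this exchange. A further rise of similar, modest size is therefore expected in this assay. The expected step is a 2.9-fold higher number from compound 2 to compound 4 (0.46 log units; beyond the scatter). For compound 4 the estimated clearance is 20 mL/min/kg, with an expected range of 6 mL/min/kg to 70 mL/min/kg.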

Compound 4, clearance: 41 mL/min/kg
Compound 4: the middle estimate sits 2.1-fold (0.31 log units) below what was measured; measured number inside the range.
By their numbers in this assay, from the lowest: compound 1; then compound 2; then compound 4; then compound 3.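

In this assay the exchange of isopropyl for cyclopentyl on a sulfonyl sulfur now has a direct reading, and it is a rise: a 5.9-fold higher number from compound 2 to compound 4 (0.77 log units; beyond the scatter) puts this change beyond the scatter. For the compounds shown here, until now the only step at this position was a 4.4-fold higher number from compound 1 to compound 2 (0.64 log units; beyond the scatter), so the new result adds a second rise in the same direction, and the whole span from ethyl to cyclopentyl reaches a 26-fold higher number from compound 1 to compound 4 (1.41 log units; beyond the scatter), which shows that the carbon group on the sulfonyl sulfur alone can move this number by a large amount across compound 1, compound 2 and compound 4. Nothing shown gives a measured reason for these rises.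

The compounds shown leave open whether the rise follows the ring itself or simply the added carbons, which an open-chain group such as n-pentyl on the same sulfonyl sulfur would separate. Also open, as far as these compounds go, is whether cyclopropyl, or a ring holding oxygen such as tetrahydropyranyl, would stay close to compound 1 at 1.6 mL/min/kg or climb as cyclopentyl does.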